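A few compounds are considered here, and "the series" means these few. Any claim that something is new, unique, unknown or untested is made for them only; others in the source may bear on it.

Working notes on the series. Compound 1 `COC(=O)[C@@]1(C)CCC=C2[C@@H]1CC[C@@H](C)[C@]2(C)Cc1c(C)[nH]c2ccc(Br)cc12` gives 15000 nM in a functional assay on A549 cells (Homo sapiens) for inhibition, read by sulforhodamine B assay, with a stated time of 48 h; a lower number here means a stronger inhibitor of growth, a higher number a weaker inhibitor of growth; compound 2 `COC(=O)[C@@]1(C)CCC=C2[C@@H]1CC[C@@H](C)[C@]2(C)Cc1c(C)[nH]c2ccc(F)cc12` gives 15000 nM. The step of no change at the digits printed from compound 1 to compound 2 (within the scatter) shows halogen exchange at this position leaves the number where it was. Compound 3 `COC(=O)[C@@]1(C)CC[C@@H]2C3=C1CC[C@@H](C)[C@]3(C)C[C@@H]1c3ccccc3N[C@H]21`, built on a different core, gives 39000 nM and stands highest of the three, its gap to compound 1 and to compound 2 beyond the scatter. Compound 4 `COC(=O)[C@@]1(C)CC[C@@H]2C3=C1CC[C@@H](C)[C@]3(C)C[C@@H]1c3cc(Cl)ccc3N[C@H]21` differs from compound 3 by chloro in place of hydrogen on an aromatic carbon. Among the measured compounds shown here, no measured step replaces hydrogen by halogen; the only halogen step bears loosely and was flat, so no step beyond the scatter is expected, and the estimated step of a 1.1-fold lower number from compound 3 to compound 4 (0.05 log units; within the scatter) is small. For compound 4 the expected value is 35000 nM, with range 12000 nM to 100000 nM.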

Compound 4, concentration for 50% growth inhibition: 35000 nM
Estimate against measurement, compound 4: no gap at the digits printed; the range from low to high includes it.
By their numbers in this assay, from the lowest: compounds 1 and 2 (each within the scatter of the next); then compounds 4 and 3 (each within the scatter of the next).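

In this assay, chloro in place of hydrogen on this aromatic carbon of the core of compound 3 gives a 1.1-fold lower number from compound 3 to compound 4 (0.05 log units; within the scatter), the only step shown that replaces hydrogen by a halogen. A chlorine atom at this position therefore leaves the number within the scatter, which the halogen exchange on the other core could not show directly. Nothing available explains why this step is flat.

From the compounds shown here alone, whether an amine, a carboxylic acid or a methoxy group on this carbon would move the number beyond the scatter stays open.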